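Piperidine to Pyrrolidine Swap in a Flavone Amine Side Chain

The compounds below may be only part of what the source reports. "The series", "measured", "known", "first", "only" and "open" are said of these compounds alone.

Compound 1 `O=c1cc(-c2ccccc2)oc2cc(O)c(OCCCN3CCCCC3)c(O)c12` carries a piperidinylpropoxy chain on the shared core, with two free hydroxyl groups. In a functional assay on BCG823 cells (Homo sapiens) for antiproliferative activity, read by MTT assay, with a stated time of 48 h (a lower number here means a stronger inhibitor, a higher number a weaker inhibitor), compound 1 gives 60900 nM. Among the measured compounds shown here, its single measured neighbour, compound 2 `O=c1cc(-c2ccccc2)oc2cc(OCc3ccccc3)c(OCCCN3CCCCC3)c(O)c12`, has a benzyl in place of hydrogen on an oxygen on an aromatic ring and gives 4600 nM; the step of a 13-fold lower number from compound 1 to compound 2 (1.12 log units; beyond the scatter) is large. Compound 1 therefore stands at the highest number of the two measured compounds.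

Compound 3 `O=c1cc(-c2ccccc2)oc2cc(O)c(OCCCCN3CCCC3)c(O)c12` differs from compound 1 at the amine end of the chain: (pyrrolidin-1-yl)methyl in place of piperidin-1-yl on a saturated chain carbon, three bonds along the chain from an oxygen on an aromatic ring. For the measured compounds named here, the one measured step here concerns a benzyl on an aromatic oxygen, not the saturated chain or its amine, so no measured step bears directly on this change. With the same atoms merely joined differently and the rest of the molecule untouched, the change from compound 1 to compound 3 is expected to give a step of a 1.2-fold lower number from compound 1 to compound 3 (0.09 log units; within the scatter), not beyond the scatter. Compound 3 is therefore estimated at 50000 nM, within 20000 nM to 150000 nM.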

Compound 3, half-maximal inhibitory concentration: 86400 nM
For compound 3 the middle estimate is 1.7-fold (0.24 log units) below the measured one, and the stated range covers the measured number.
By their numbers in this assay, from the lowest: compound 2; then compounds 1 and 3 (each within the scatter of the next).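

In this assay, the change at the amine end of the chain, (pyrrolidin-1-yl)methyl in place of piperidin-1-yl on a saturated chain carbon, gives a 1.4-fold higher number from compound 1 to compound 3 (0.15 log units; within the scatter), which lies within the scatter, so compound 1 and compound 3 cannot be told apart in this assay. This is the first reading at this end of the molecule, and it shows that 3-(piperidin-1-yl)propyl and 4-(pyrrolidin-1-yl)butyl are interchangeable here when the two hydroxyl groups of compound 1 are kept, while the one large step among the listed compounds remains the benzyl on the aromatic oxygen, a 13-fold lower number from compound 1 to compound 2 (1.12 log units; beyond the scatter). No independent measurement is available to explain this result.

Because the ring and the chain differ together in compound 3, the compounds shown do not separate a pyrrolidine on the propyl chain or a piperidine on the butyl chain from the pair already read. On these data alone, it also remains open whether the same equivalence would hold with the benzyl group of compound 2 in place, or with a morpholine or a dimethylamino group at the chain end.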